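The compounds below may be only part of what the source reports. "The series", "measured", "known", "first", "only" and "open" are said of these compounds alone.

Measured compounds in this series:
- compound 1, `CCOC(=O)/C=C(C)/C=C/CC(C)CCCC(C)(C)OC`: 5.54
- compound 2, `CCOC(=O)/C=C(C)/C=C/CC(C)CCCC(C)(C)OCC`: 6.08
- compound 3, `CCOC(=O)/C=C(C)/C=C/CC(C)CCCC(C)CC`: 7.81

In a physicochemical assay for lipophilicity (a lower number here means a more polar compound, a higher number a more lipophilic compound), compound 1 stands lowest of the three. Its nearest neighbour is compound 2, with a number 0.54 log units higher from compound 1 to compound 2 (beyond the scatter) for methyl in place of hydrogen on a saturated chain carbon bound to an oxygen on a saturated carbon. The furthest is compound 3, with a number 2.27 log units higher from compound 1 to compound 3 (beyond the scatter) for sec-butyl in place of 1-methoxy-1-methylethyl on a saturated chain carbon, five bonds along the chain from a double-bonded chain carbon; the related step from compound 2 reads a number 1.73 log units higher from compound 2 to compound 3 (beyond the scatter).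

Compound 4, `CCNC(=O)/C=C(C)/C=C/CC(C)CCCC(C)(C)OC`, is not yet measured. It differs from compound 1 at the other end of the molecule: ethylamino in place of ethoxy on a carbonyl carbon

Among the compounds with values here, none of the measured steps touches the carbonyl carbon; all three alter the chain end of the shared core of compound 1, so they give no direct reading on this change. The difference counted above removes one hydrogen-bond acceptor and adds one hydrogen-bond donor, a change that generally reads as a decrease in this assay. The expected step is therefore downward, beyond the scatter, estimated as a number 1.14 log units lower from compound 1 to compound 4 (beyond the scatter).

For compound 4 the estimate in this assay is 4.4, within 3.8 to 5.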

Compound 4, partition coefficient: 4.04
Estimate against measurement, compound 4: 0.36 log units above; low and high end bracket the measured number.
By their numbers in this assay, from the lowest: compound 4; then compound 1; then compound 2; then compound 3.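

The carbonyl end of the molecule now has a reading of its own in this assay: ethylamino in place of ethoxy on a carbonyl carbon gives a number 1.50 log units lower from compound 1 to compound 4 (beyond the scatter), the first listed step out of compound 1 that runs downward. In size it stands beyond the methyl step at the chain end, a number 0.54 log units higher from compound 1 to compound 2 (beyond the scatter), though the exchange of the whole chain end, a number 2.27 log units higher from compound 1 to compound 3 (beyond the scatter), remains the larger move and runs the opposite way. The entering and leaving groups have the same heavy-atom count, and no measurement in hand accounts for the size of this step.

On these data alone, the exchange has been read only with the chain end of compound 1, so whether it carries over to the chain end of compound 2 or the sec-butyl chain end of compound 3 stays open. Also open, as far as these compounds go, is how this position responds to other groups on the carbonyl carbon, such as a hydroxyl giving the carboxylic acid, dimethylamino, or a longer chain in butylamino.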